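A few compounds are considered here, and "the series" means these few. Any claim that something is new, unique, unknown or untested is made for them only; others in the source may bear on it.

Working notes on the series. In a functional assay on CCRF-CEM cells (Homo sapiens), read by MTT assay, with a stated time of 72 h (on this read-out lower numbers stand for stronger inhibition and higher numbers for weaker inhibition), compound 1 `C#Cc1cn([C@@H]2O[C@H](CO)[C@@H](O)[C@H]2O)c2ncnc(N(C)C)c12` gives 90 nM. For compound 2 `CSc1ncnc2c1c(-c1cccs1)cn2[C@@H]1O[C@H](CO)[C@@H](O)[C@H]1O` this assay reports only a limit, > 20000 nM, as the evidence notes (the limit of > 20000 nM in this assay, at which 1 of the 2 values shown sits). Compound 3 `CN(C)c1ncnc2c1c(-c1cccs1)cn2[C@@H]1O[C@H](CO)[C@@H](O)[C@H]1O` differs from compound 2 in one place: dimethylamino in place of methylsulfanyl on an aromatic carbon. Among the compounds with values here, no measured pair covers this change on its own; compound 1 also carries dimethylamino and gives 90 nM in this assay, yet differs from compound 3 in a second place as well. A gain beyond the scatter is expected, an at least 33-fold lower number from compound 2 to compound 3 (1.52 log units; beyond the scatter), with wide uncertainty. Compound 3 is estimated at 600 nM, between 60 nM and 20000 nM.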

Compound 3, half-maximal inhibitory concentration: > 20000 nM
Compound 3: no number, only a limit; the forecaster's own chance of this, stated with the estimate: 25%; middle value at least 33-fold (1.52 log units) from the limit.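

In this assay, with dimethylamino on both compounds, thiophen-2-yl in place of ethynyl on an aromatic carbon gives an at least 220-fold higher number from compound 1 to compound 3 (2.34 log units; beyond the scatter). Dimethylamino therefore does not keep activity on its own: compound 3 reads > 20000 nM, which is a limit and not a number. The step from methylsulfanyl to dimethylamino cannot be read, since compound 2 and compound 3 both stand at the limit: the limit of > 20000 nM in this assay, at which 2 of the 3 values shown sit.

Open, from the compounds shown here alone, is how dimethylamino and methylsulfanyl compare with ethynyl in place. Also open, going by these compounds, is how a methyl or phenyl group would read where thiophen-2-yl sits.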